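Swapping an Isobutyl Chain for a Methoxyethoxy Chain

The source may report more compounds than this note shows. Statements on the series, on what has been measured and on what is new or still open speak of the compounds shown alone.

Compound 1 `C[C@@H](Oc1cc2onc(CCC(=O)O)c2cc1Cl)c1ccc(F)cn1` in an assay on HEK293 cells for inhibition of kynurenine 3-monooxygenase (Homo sapiens), read by LC-MS, with a stated time of 20 h; a lower number here means a stronger inhibitor, a higher number a weaker inhibitor: 31.6 nM
Compound 2 `CC(C)Cc1cc2oc(=O)n(CCC(=O)O)c2cc1Cl` in this assay: 794 nM
Compound 3 `C[C@@H](Oc1cc2onc(CCC(=O)O)c2cc1Cl)c1ccc(Cl)cn1` in this assay: 3.98 nM

Compound 2 has the highest number of the three, so it is the weakest inhibitor here; compound 1 is nearest to it and compound 3 furthest, both gaps beyond the scatter. Among the measured compounds shown here, the only measured step, a 7.9-fold lower number from compound 1 to compound 3 (0.90 log units; beyond the scatter), swaps one halogen for another on a different core and says nothing about the change now in question. Compound 4 `COCCOc1cc2oc(=O)n(CCC(=O)O)c2cc1Cl` differs from compound 2 by 2-methoxyethoxy in place of isobutyl on an aromatic carbon. For the measured compounds named here, no measured step bears on this change, so no shift beyond the scatter is expected, only a wide range. Compound 4 is therefore estimated at 794 nM, between 200 nM and 3200 nM, which amounts to no change at the digits printed from compound 2 to compound 4 (within the scatter).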

Compound 4, half-maximal inhibitory concentration: 50100 nM
For compound 4 the middle estimate is 63-fold (1.80 log units) below the measured one; measured number above the stated range.
By their numbers in this assay, from the lowest: compound 3; then compound 1; then compound 2; then compound 4.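

Putting 2-methoxyethoxy in place of isobutyl gives a 63-fold higher number from compound 2 to compound 4 (1.80 log units; beyond the scatter) in this assay, so these two chains are far from interchangeable on this aromatic carbon. The entering chain brings oxygen atoms and hydrogen-bond acceptors that isobutyl lacks, but a single pair cannot show which of these differences matters. No measurement shown accounts for the loss.

Going by these compounds, it remains open whether an all-carbon chain, a lone methoxy group or an amine here would retain the strength of compound 2. On these data alone, whether the same swap would act alike on the core of compound 1 is also open.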